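This account rests on a few compounds, and the source may have more. Where it says the series, first, only, none or still open, it means among the compounds named here.

Going by the values given here, compound 2 `COc1ccc2ncc(S(=O)(=O)c3cc(F)cc(F)c3)c(N3CCC(C)CC3)c2c1` stands lowest of the three numbers known in an assay on isolated protein for displacement of a labelled ligand from metabotropic glutamate receptor 5 (Homo sapiens), with a stated time of 60 min, tested at 1 uM; a higher number here means more inhibition at the concentration tested (going by the name of the read-out), a lower number less inhibition: in this assay compound 2 gives 30%. Compound 1 `COc1ccc2ncc(S(=O)(=O)c3ccc(C)c(F)c3)c(N3CCC(C)CC3)c2c1` gives 73% in this assay, and compound 3 `Cc1ccc2ncc(S(=O)(=O)c3cc(F)cc(F)c3)c(N3CCC(C)CC3)c2c1` gives 72%. Both measured steps are large: a number 43 percentage points lower from compound 1 to compound 2 (beyond the scatter) with 3,5-difluorophenyl in place of 3-fluoro-4-methylphenyl on a sulfonyl sulfur, and a number 42 percentage points higher from compound 2 to compound 3 (beyond the scatter) with methyl in place of methoxy on an aromatic carbon. Compound 4 `COc1ccc2ncc(S(=O)(=O)c3cc(Cl)cc(Cl)c3)c(N3CCC(C)CC3)c2c1` differs from compound 2 by 3,5-dichlorophenyl in place of 3,5-difluorophenyl on a sulfonyl sulfur. Among the compounds with values here, only the step from compound 1 to compound 2 concerns the group on a sulfonyl sulfur, and it shows that a change there can move the number by a large amount; no measured step exchanges one halogen for another, so the direction of the present change is open. Compound 4 is therefore expected to fall near the middle of the known spread, estimated at 45%, between 20% and 70%. That expectation amounts to a number 15 percentage points higher from compound 2 to compound 4 (beyond the scatter), a step expected to be modest and possibly within the scatter.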

Compound 4, a percentage reported as inhibition, at one concentration (the size of the read-out at that concentration, not a potency): 87%
The estimate for compound 4 lay 42 percentage points below the measured number; the measured number lies above the stated range.
By their numbers in this assay, from the lowest: compound 2; then compounds 3 and 1 (each within the scatter of the next); then compound 4.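

In this assay, 3,5-dichlorophenyl in place of 3,5-difluorophenyl on a sulfonyl sulfur gives a number 57 percentage points higher from compound 2 to compound 4 (beyond the scatter), so at this place an exchange of fluorine for chlorine, with the count of heavy atoms unchanged, moves the number by a large amount. The step of a number 14 percentage points higher from compound 1 to compound 4 (beyond the scatter) shows that leaving 3-fluoro-4-methylphenyl does not always lower the number: on the same core, one replacement lowers it and the other raises it. Nothing available explains why the two halogenated groups differ so widely.

As far as these compounds go, whether 3,5-dichlorophenyl would give a similar gain with methyl in place of methoxy on the aromatic carbon remains open. From the compounds shown here alone, it is also open how 3,5-dibromophenyl, 3-chlorophenyl or 3,5-dimethylphenyl on the sulfonyl sulfur would compare.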